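Swapping the amine side chain back to a carboxamide

The source may report more compounds than this note shows. Statements on the series, on what has been measured and on what is new or still open speak of the compounds shown alone.

Compound 1 `NC(=O)C1CCN(c2nc(-c3ccccn3)nc3c2CN(Cc2ccccc2)CC3)CC1` and compound 2 `CN(C)CCN1CCN(c2nc(-c3ccccn3)nc3c2CN(Cc2ccccc2)CC3)CC1` share the same core and differ only in the group on the aromatic carbon that sits next to the ring nitrogen. In an assay on A549 cells with Cystic fibrosis transmembrane conductance regulator variant F508del (Homo sapiens) as the target, read by fluorescence, with a stated time of 25 min (on this read-out higher numbers stand for larger maximal responses and lower numbers for smaller maximal responses), compound 1 gives 34.4%, while compound 2 gives 57%, so the exchange of 4-carbamoylpiperidin-1-yl for 4-(2-(dimethylamino)ethyl)piperazin-1-yl is recorded as a number 22.6 percentage points higher from compound 1 to compound 2 (beyond the scatter).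

Compound 3 `COc1ccc(CN2CCc3nc(-c4ccccn4)nc(N4CCN(CCN(C)C)CC4)c3C2)cc1` carries the same 4-(2-(dimethylamino)ethyl)piperazin-1-yl group but a different benzyl substituent on the saturated ring; in this assay compound 3 is reported as "not active" (no number reported), with no number attached, so it stands at the bottom of the series without a value to rank.

Compound 4 `COc1ccc(CN2CCc3nc(-c4ccccn4)nc(N4CCC(C(N)=O)CC4)c3C2)cc1` arises from compound 3 by the change (4-carbamoylpiperidin-1-yl in place of 4-(2-(dimethylamino)ethyl)piperazin-1-yl on an aromatic carbon). This is the mirror of the step from compound 1 to compound 2, which raised the maximal response by a modest but real amount, so the same exchange run the other way would be expected to lower the response. Since compound 3 already shows no measurable response, compound 4 is expected to remain low or inactive in this assay, estimated at 10% with a range from 0% to 30%.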

Compound 4, largest response reached (Emax), in percent of the reference or control that the assay uses: "not active" (no number reported)
Nothing numeric was reported for compound 4; the estimate stays without a comparison.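

No step can be read between compound 3 and compound 4: in this assay compound 3 stands as "not active" (no number reported) and compound 4 as "not active" (no number reported) with nothing to compare. Nothing at hand bears on this result. The compounds shown leave open whether this exchange of groups changes the maximal response at all when the benzyl substituent of compound 3 is present.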